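A few compounds are considered here, and "the series" means these few. Any claim that something is new, unique, unknown or untested is made for them only; others in the source may bear on it.

The series shares one core, a biphenyl urea carrying a carbonyl substituent, and is read in a functional assay on HepG2 cells (Homo sapiens) for inhibition, read by MTT assay, with a stated time of 120 h; on this read-out higher numbers stand for weaker inhibition and lower numbers for stronger inhibition. Compound 1 `CC1CN(C(=O)c2ccc(-c3ccc(NC(=O)Nc4ccc(Cl)c(C(F)(F)F)c4)cc3)cc2)CC(C)O1` gives 31100 nM in this assay. Compound 2 `CC(NC(=O)c1ccc(-c2ccc(NC(=O)Nc3cc(C(F)(F)F)ccc3Cl)cc2)cc1)c1ccccc1` gives 18400 nM, and compound 3 `CC(NC(=O)c1ccc(-c2ccc(NC(=O)Nc3ccc(Cl)c(C(F)(F)F)c3)cc2)cc1)c1ccccc1` gives 16800 nM. The number for compound 2 falls between those of the other two, and both gaps, to compound 3 and to compound 1, lie within the scatter, so no ordering among the three can be claimed.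

Compound 4 `CC1CN(C(=O)c2ccc(-c3ccc(NC(=O)Nc4cc(C(F)(F)F)ccc4Cl)cc3)cc2)CC(C)O1` is not yet measured in this assay. It differs from compound 2 by 2,6-dimethylmorpholin-4-yl in place of (1-phenylethyl)amino on a carbonyl carbon. Among the compounds with values here, one measured step bears on this change directly, in the opposite direction: a 1.9-fold lower number from compound 1 to compound 3 (0.27 log units; within the scatter). The other measured step, a 1.1-fold lower number from compound 2 to compound 3 (0.04 log units; within the scatter), concerns the aryl group on the urea and shows that the two aryl patterns in this series give numbers that cannot be told apart.

Reversing the first of these steps, one would expect compound 4 to give a somewhat higher number than compound 2, with a 1.8-fold higher number from compound 2 to compound 4 (0.27 log units; within the scatter) as the expected step, though a change of this size could still lie within the scatter. The estimate for compound 4 in this assay is therefore 34000 nM, with a range from 15000 nM to 80000 nM.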

Compound 4, half-maximal inhibitory concentration: > 50000 nM
Compound 4: no number, only a limit; the forecaster's own chance of this, stated with the estimate: 10%; at least 1.4-fold (0.16 log units) between middle value and limit.
By their numbers in this assay, from the lowest: compounds 3, 2 and 1 (each within the scatter of the next). At a limit, above all of these: compound 4.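

In this assay, exchanging (1-phenylethyl)amino for 2,6-dimethylmorpholin-4-yl now gives a step that clears the scatter, with weaker inhibition on the side of compound 4: an at least 2.7-fold higher number from compound 2 to compound 4 (0.43 log units; beyond the scatter). The earlier compounds shown here showed this exchange only within the scatter, and it can now be compared on two cores: the same change on two cores in this assay, a 1.9-fold lower number (0.27 log units; within the scatter) from compound 1 to compound 3 and an at least 2.7-fold lower number (0.43 log units; beyond the scatter) from compound 4 to compound 2; the limit leaves it open whether they differ. The change of aryl group on the amide-type nitrogen, by contrast, still gives no step that can be told from the scatter, as an at least 1.6-fold higher number from compound 1 to compound 4 (0.20 log units; that floor lies within the scatter) shows only a floor, so the aryl pattern has not been shown to matter on either core: the same change on two cores in this assay, a 1.1-fold lower number (0.04 log units; within the scatter) from compound 2 to compound 3 and an at least 1.6-fold lower number (0.20 log units; that floor lies within the scatter) from compound 4 to compound 1; the limit leaves it open whether they differ.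

On these data alone, compound 4 gives only a limit, > 50000 nM, so the full size of both new steps stays open. Also open, as far as these compounds go, is whether the loss follows the dimethylmorpholine itself or the exchange of a secondary amide for a tertiary one, and a plain morpholin-4-yl, a piperazin-1-yl or a benzylamino group on the same carbonyl carbon would be needed to separate these readings.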